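A few compounds are considered here, and "the series" means these few. Any claim that something is new, unique, unknown or untested is made for them only; others in the source may bear on it.

Compound 1 `Cc1cccc(-c2ccc(NC[C@H]3CC[C@]4(CC3)CN(c3cccnn3)C(=O)O4)nc2)n1` gives 0.251 nM in a functional assay for antagonist activity at Neuropeptide Y receptor type 5 (Homo sapiens); a higher number here means a weaker inhibitor, a lower number a stronger inhibitor.
Compound 2 `Cc1ncccc1N1C[C@]2(CC[C@@H](CNc3cnn(-c4ccccc4F)c3)CC2)OC1=O` gives 0.631 nM in this assay.
Compound 3 `O=C1O[C@]2(CC[C@H](CNc3ccc(-c4ncccn4)cn3)CC2)CN1c1ccccn1` gives 0.159 nM in this assay.

All three share the same spiro core and differ in the aromatic group on the ring nitrogen of the cyclic carbamate and in the aryl-amine end. Among them, compound 2 stands at the highest number, that is, it is the weakest inhibitor of the three: compound 1 lies at a number beyond the scatter below it, and compound 3 further still.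

Compound 4 `O=C1O[C@]2(CC[C@H](CNc3cnn(-c4ccccc4F)c3)CC2)CN1c1cccnn1` has not been measured yet. It keeps the fluorophenyl-pyrazole end of compound 2 and changes only one place: pyridazin-3-yl in place of 2-methylpyridin-3-yl on an amide-type nitrogen in a ring. Among the compounds with values here, the pyridazin-3-yl group is the one found in compound 1, which sits at a lower number than compound 2, but that comparison also involves a different aryl-amine end, so no clean step for this single change is available. A modest move toward a lower number is expected, a 1.8-fold lower number from compound 2 to compound 4 (0.26 log units; within the scatter), though it may fall within the scatter. For compound 4 the expected value in this assay is 0.35 nM, with a range from 0.12 nM to 1 nM.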

Compound 4, inhibition constant: 0.1 nM
Compound 4: middle estimate off by 3.5-fold (0.54 log units), on the high side; the whole stated range lies above it.
By their numbers in this assay, from the lowest: compounds 4, 3 and 1 (each within the scatter of the next, the first and the last beyond it); then compound 2.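

Within the data shown here, with the fluorophenyl-pyrazole end held fixed, pyridazin-3-yl in place of 2-methylpyridin-3-yl on the amide-type nitrogen in the ring gives, in this assay, a 6.3-fold lower number from compound 2 to compound 4 (0.80 log units; beyond the scatter) and this is the first reading of this place alone, as the earlier compounds all differ in more than one place. The group on this nitrogen can therefore by itself move the number beyond the usual scatter, but this single step cannot separate losing the methyl from gaining a second ring nitrogen. No measurement shown here accounts for the change.

A pyridin-3-yl group, with one ring nitrogen and no methyl, would help to tell those two parts apart. Going by these compounds, whether the same swap gives a similar step with a different aryl-amine end also remains open.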